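Swapping a bicyclic group for fluorophenyl on the shared core

The source may hold more compounds than are shown below. What is called first, only, known or untested is meant among the compounds shown, and "the series" means these compounds.

Measured compounds:
compound 1, `O=C1COc2ccc(-c3nn(-c4ccc(Br)cc4)cc3-c3ccccc3)cc2N1`, 58.8%
compound 2, `O=C1COc2ccc(-c3[nH]c(-c4c[nH]c5ncccc45)nc3-c3ccccc3)cc2N1`, 86.8%
compound 3, `O=C1COc2ccc(-c3nn(-c4ccccc4)cc3-c3ccccc3)cc2N1`, 59.7%

In a functional assay on A549 cells (Homo sapiens) for cytotoxicity, read by colorimetric assay and MTT assay, with a stated time of 3 days, tested at 20 uM (on this read-out lower numbers stand for a stronger effect and higher numbers for a weaker effect at the one concentration tested), compound 2 gives the highest of the three numbers, that is the weakest effect, and its gap to each of the other two lies beyond the scatter. Among the measured compounds shown here, the only single-site step recorded, a number 0.9 percentage points higher from compound 1 to compound 3 (within the scatter), concerns a different ring and a different change, so it does not bear on the move examined here.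

Compound 4, `O=C1COc2ccc(-c3[nH]c(-c4ccc(F)cc4)nc3-c3ccccc3)cc2N1`, has not yet been measured. It differs from compound 2 in one place: a group of 7 heavy atoms (6 carbon, 1 fluorine; one six-membered aromatic ring of carbon only) in place of a group of 9 heavy atoms (7 carbon, 2 nitrogen; one five-membered aromatic ring with 1 hetero atom, one six-membered aromatic ring with 1 hetero atom), on an aromatic carbon. For the measured compounds named here, there is no measured step of this kind, so the direction is open. Compounds 1 and 3, which also carry an aryl group on their five-membered ring, sit well below compound 2, which speaks for some lowering, but their core is not the same. The expected step is a number 16.8 percentage points lower from compound 2 to compound 4 (beyond the scatter), with a wide range. Compound 4 is therefore estimated at 70%, between 50% and 90%.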

Compound 4, a percentage reported as activity, at one concentration (the size of the read-out at that concentration, not a potency): 37.5%
The estimate for compound 4 lay 32.5 percentage points above the measured number; the whole stated range lies above it.
By their numbers in this assay, from the lowest: compound 4; then compounds 1 and 3 (each within the scatter of the next); then compound 2.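

On the shared core, the aromatic carbon between two ring nitrogen atoms proves sensitive to the group it carries: in this assay, 4-fluorophenyl in place of the two-ring group gives a number 49.3 percentage points lower from compound 2 to compound 4 (beyond the scatter) and so a clearly stronger effect at the one concentration tested. The change replaces a group with a hydrogen-bond donor and acceptor by a single carbon-only ring that has neither, and this exchange alone separates the two compounds. Nothing available explains why the number falls so far.

Still open, on these data alone, is which part of the exchange matters: the loss of the second ring, the loss of the ring nitrogen atoms or the gain of fluorine. Plain phenyl, pyridyl or a small chain such as methyl on this carbon would help to separate these possibilities.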